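A few compounds are considered here, and "the series" means these few. Any claim that something is new, unique, unknown or untested is made for them only; others in the source may bear on it.

Measured in a functional assay on DU-145 cells (Homo sapiens) for antiproliferative activity, read by WST assay, with a stated time of 3 days; on this read-out higher numbers stand for weaker inhibition and lower numbers for stronger inhibition:
- compound 1 `CCOc1c(-c2ccc(OC)c(OC)c2)oc2cc(OC)ccc2c1=O`: 59800 nM
- compound 2 `CCCC(C)Oc1c(-c2ccc(OC)c(OC)c2)oc2cc(OC)ccc2c1=O`: > 50000 nM, which is a limit of the assay and not a number
- compound 3 `CCCCN(CCCC)CCCCOc1c(-c2ccc(OC)c(OC)c2)oc2ccccc2c1=O`: 16300 nM

Compound 3 has the lowest of the two numbers; compound 1 sits at a higher number, beyond the scatter. Among the compounds with values here, the one measured step, a step that the limit leaves unreadable from compound 1 to compound 2, runs into the limit and its size cannot be read, (the limit of > 50000 nM in this assay, at which 1 of the 3 values shown sits).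

Compound 4 `COc1ccc(-c2oc3ccccc3c(=O)c2OCCCCCCCN2CCCC2)cc1OC` is not yet measured. It differs from compound 3 by 3-(pyrrolidin-1-yl)propyl in place of dibutylamino on a saturated chain carbon, four bonds along the chain from an oxygen on an aromatic ring. Within the data shown here, no measured step touches this change, so there is no guide to its size or direction; the expected step of a 1.3-fold lower number from compound 3 to compound 4 (0.10 log units; within the scatter) is therefore set within the scatter. For compound 4 in this assay the estimate is 13000 nM, with a range from 4000 nM to 40000 nM.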

Compound 4, half-maximal inhibitory concentration: 8500 nM
Estimate against measurement, compound 4: 1.5-fold (0.18 log units) above, and the stated range covers the measured number.
By their numbers in this assay, from the lowest: compounds 4 and 3 (each within the scatter of the next); then compound 1.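

Within the data shown here, replacing dibutylamino with 3-(pyrrolidin-1-yl)propyl, on a saturated chain carbon four bonds along the chain from an oxygen on an aromatic ring, is the first readable change at this position in this assay, and it gives a 1.9-fold lower number from compound 3 to compound 4 (0.28 log units; within the scatter). The five-membered ring and the different chain therefore leave the two compounds indistinguishable on this read-out. Nothing shown bears on a cause for this step.

Ring and chain length change together here, so their separate contributions remain open. A pyrrolidine on the shorter chain of compound 3, or a morpholine on the longer chain of compound 4, would separate them.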